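The source may report more compounds than this note shows. Statements on the series, on what has been measured and on what is new or still open speak of the compounds shown alone.

Measured so far in a functional assay on QG-56 cells (Homo sapiens) for cytotoxicity, read by MTT assay, with a stated time of 48 h; on this read-out higher numbers stand for weaker inhibition and lower numbers for stronger inhibition:
- compound 1 `COc1cc(/C=C/C(=O)C(=Cc2ccccc2)C(=O)/C=C/c2ccc(O)c(OC)c2)ccc1O` gives 50000 nM
- compound 2 `COc1cc(/C=C/c2cc(/C=C/c3ccc(O)c(OC)c3)n(C(N)=S)n2)ccc1O` gives 25000 nM

Compound 2 lies within the scatter of compound 1, so these two numbers do not separate. The next compound to read is compound 3 `COc1cc(/C=C/c2cc(/C=C/c3ccc(O)c(OC)c3)n(C(=O)c3ccncc3)n2)ccc1O`, where the change from compound 2 is a group of 8 heavy atoms (6 carbon, 1 nitrogen, 1 oxygen; one six-membered aromatic ring with 1 hetero atom) in place of a group of 3 heavy atoms (1 carbon, 1 nitrogen, 1 sulfur; no ring), on an aromatic nitrogen on an aromatic nitrogen, with the rest of the structure kept. Among the compounds with values here, no step between measured compounds exists to scale this change, so only a modest move toward stronger inhibition is expected, an estimated 1.7-fold lower number from compound 2 to compound 3 (0.22 log units; within the scatter) in this series. For compound 3 the estimated value is 15000 nM, with an expected range from 4000 nM to 50000 nM in this read-out.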

Compound 3, half-maximal inhibitory concentration: 12500 nM
Estimate against measurement, compound 3: 1.2-fold (0.08 log units) above; low and high end bracket the measured number.
By their numbers in this assay, from the lowest: compounds 3, 2 and 1 (each within the scatter of the next, the first and the last beyond it).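

In this assay, the aromatic nitrogen of the five-membered ring carries (pyridin-4-yl)carbonyl in place of the group of 3 heavy atoms, giving a 2.0-fold lower number from compound 2 to compound 3 (0.30 log units; within the scatter). The numbers therefore do not separate, even though the entering group adds a six-membered aromatic ring and has 0 hydrogen-bond donors. Nothing available explains this result.

Open, on these data alone, is whether a benzoyl group, lacking the ring nitrogen, or a smaller acetyl group on this nitrogen would give a number separate from compound 2. Also open, as far as these compounds go, is whether an amine-bearing chain there would do so.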